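Chloro for methoxy on the terminal ring of compound 1

A few compounds are considered here, and "the series" means these few. Any claim that something is new, unique, unknown or untested is made for them only; others in the source may bear on it.

Compound 1 `COc1ccc(-c2ccc(-c3ccc(C(=N)N)cc3)s2)cc1` is the starting point of this step. In a functional assay on NCI-H460 cells (Homo sapiens) for inhibition, read by sulforhodamine B assay, with a stated time of 48 h (a higher number here means a weaker inhibitor of growth, a lower number a stronger inhibitor of growth), compound 1 gives 204 nM, the lowest of the three numbers in hand. Compound 2 `N=C(N)c1ccc(-c2ccc(-c3cc(Cl)cc(Cl)c3)s2)cc1` gives 375 nM, which lies within the usual scatter of the value for compound 1, so no order between the two is claimed. Going by the values given here, compound 3 `COc1ccc(-c2ccc(-c3ccc(C(=N)N)c(F)c3)s2)cc1` gives 2430 nM; the step of a 12-fold higher number from compound 1 to compound 3 (1.08 log units; beyond the scatter) is the only single-point change measured so far, and it concerns a different position of the shared core, so it does not bear directly on the change considered here.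

Compound 4 `N=C(N)c1ccc(-c2ccc(-c3ccc(Cl)cc3)s2)cc1` is not yet measured. It differs from compound 1 by chloro in place of methoxy on an aromatic carbon. Among the compounds with values here, no measured step covers this change; the nearest guide is that the values of compound 1 and compound 2 sit within the scatter of each other. Accordingly no step beyond the scatter is expected in this assay, the estimate for compound 4 being 260 nM with a range of 110 nM to 650 nM. The expected step is a 1.3-fold higher number from compound 1 to compound 4 (0.11 log units; within the scatter), small and uncertain in direction.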

Compound 4, concentration for 50% growth inhibition: 193 nM
Estimate against measurement, compound 4: 1.3-fold (0.13 log units) above; measured number inside the range.
By their numbers in this assay, from the lowest: compounds 4, 1 and 2 (each within the scatter of the next); then compound 3.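

In this assay, the change on the aromatic carbon para to a large group gives a 1.1-fold lower number from compound 1 to compound 4 (0.02 log units; within the scatter), so methoxy and chloro cannot be told apart here, even though the entering group brings no hydrogen-bond acceptor and has fewer heavy atoms. This position therefore accepts this exchange, unlike the change elsewhere on the shared core, which gives a 12-fold higher number from compound 1 to compound 3 (1.08 log units; beyond the scatter), so a small single-point change is not read alike at every place. Nothing measured on these compounds accounts for the match between methoxy and chloro.

From the compounds shown here alone, whether an amine or a carboxylic acid on this carbon would also stay within the scatter of compound 1 remains open. So does the reading for a longer chain, such as butoxy, in the same place.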